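This account rests on a few compounds, and the source may have more. Where it says the series, first, only, none or still open, it means among the compounds named here.

Values in a functional assay on PC-9 cells (Homo sapiens) for inhibition, read by MTT assay, with a stated time of 72 h; a higher number here means a weaker inhibitor, a lower number a stronger inhibitor:
- Compound 1 `Cc1cc(Nc2ccn(Cc3ccccc3)n2)n2nc(SCc3ccc(Br)cc3)nc2n1`: > 50000 nM, which is a limit of the assay.
- Compound 2 `Cc1cc(Nc2cc(-c3ccccc3)[nH]n2)n2nc(SCC(=O)c3ccccc3)nc2n1`: 4450 nM
- Compound 3 `Cc1cc(Nc2cc(C(C)(C)C)[nH]n2)n2nc(SCc3ccc(Br)cc3)nc2n1`: 12400 nM

Of the two numerical values, the lower belongs to compound 2 at 4450 nM. Compound 3 reads higher at 12400 nM, a gap beyond the usual scatter.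

Compound 4 `Cc1cc(Nc2cc(-c3ccccc3)[nH]n2)n2nc(SCc3nc4ccccc4[nH]3)nc2n1` is the next to be read against compound 2, with 1H-benzimidazol-2-yl in place of benzoyl on a saturated chain carbon bound to a sulfur.

Going by the values given here, no measured step covers this change, so no shift beyond the scatter is expected in this assay, and the expectation stays anchored on compound 2 at 4450 nM. The expected step is a 1.1-fold lower number from compound 2 to compound 4 (0.05 log units; within the scatter). For compound 4 the estimated value is 4000 nM, with an expected range of 1200 nM to 15000 nM.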

Compound 4, half-maximal inhibitory concentration: 4840 nM
For compound 4 the middle estimate is 1.2-fold (0.08 log units) below the measured one; the measured number falls inside the stated range.
By their numbers in this assay, from the lowest: compounds 2 and 4 (each within the scatter of the next); then compound 3. At a limit, above all of these: compound 1.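

In this assay, going by these compounds alone, this is the first comparison that differs in one place: 1H-benzimidazol-2-yl in place of benzoyl on a saturated chain carbon bound to a sulfur gives a 1.1-fold higher number from compound 2 to compound 4 (0.04 log units; within the scatter). At this place, then, losing the carbonyl and gaining a five-membered aromatic ring and a hydrogen-bond donor leaves the number within the scatter. Nothing in the data shown speaks to a cause for this step.

From the compounds shown here alone, how an amine, a carboxylic acid or a longer chain would read at this place stays open. So does whether the same change reads alike outside the compound 2 framework.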